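Loss of a ring hydroxy in a cytotoxicity series

The source may hold more compounds than are shown below. What is called first, only, known or untested is meant among the compounds shown, and "the series" means these compounds.

Measured compounds:
compound 1 `COc1cc(/C=C/C(=O)OC[C@H](Cc2ccc(O)c(OC)c2)[C@H](CO)Cc2ccc(O)c(OC)c2)ccc1O` — 20.9 ug/mL
compound 2 `C=C[C@@]1(C)COC(=O)C1(O)C(=O)/C=C(\O)c1ccccc1` — 53.1 ug/mL

Of the compounds shown here, two have been tested in a functional assay on KB-C2 cells (Homo sapiens) for cytotoxicity, read by MTT assay, with a stated time of 48 h, in the presence of a further agent that is not named here; a lower number here means a stronger inhibitor, a higher number a weaker inhibitor. Compound 1 gives 20.9 ug/mL, whereas compound 2 gives 53.1 ug/mL, the higher of the two numbers and therefore the weaker inhibitor; the gap between compound 1 and compound 2 lies beyond the scatter of repeated measurements.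

The next compound, compound 3 `C=C[C@@]1(C)COC(=O)C1C(=O)/C=C(\O)c1ccccc1`, is compound 2 with one alteration: hydrogen in place of hydroxy on a saturated ring carbon. For the measured compounds named here, no measured pair in this set shows what removing a hydroxy from such a position does, so there is no precedent to lean on. Without such guidance the most cautious expectation is a step of modest size, most likely within the scatter, in either direction. Compound 3 is therefore expected to give 45 ug/mL in this assay, within the range 20 ug/mL to 110 ug/mL, and the estimated change a 1.2-fold lower number from compound 2 to compound 3 (0.07 log units; within the scatter) is small.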

Compound 3, half-maximal inhibitory concentration: 24.6 ug/mL
The estimate for compound 3 lay 1.8-fold (0.26 log units) above the measured number, and the stated range covers the measured number.
By their numbers in this assay, from the lowest: compounds 1 and 3 (each within the scatter of the next); then compound 2.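

In this assay, for the compounds shown here, the loss of the hydroxy on this saturated ring carbon, two ring bonds from the ring oxygen, gives a 2.2-fold lower number from compound 2 to compound 3 (0.33 log units; beyond the scatter) and is the first single change that can be read. The hydroxy is therefore not needed for the activity seen here, and the compound without it is the stronger inhibitor of this pair, by a modest step. Nothing available explains why the number falls when the hydroxy leaves.

Going by these compounds, whether a methoxy, an amine or a fluorine on the same carbon would move the number further, or reverse the step, remains open. So does whether the same change would have a similar effect on a different core, since compound 1 differs from the other two in more than one place and offers no comparison.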